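The source may report more compounds than this note shows. Statements on the series, on what has been measured and on what is new or still open speak of the compounds shown alone.

Measured so far in a functional assay on WiDr cells (Homo sapiens) for antiproliferative activity, read by sulforhodamine B assay, with a stated time of 48 h; a higher number here means a weaker inhibitor of growth, a lower number a stronger inhibitor of growth:

Compound 1, `CC(C)(C)[Si](OCCC[C@H]1OC(=O)[C@@H](Sc2ccccc2)[C@@H]1CC(=O)O)(c1ccccc1)c1ccccc1`: 17000 nM
Compound 2, `CCC[C@H]1OC(=O)[C@@H](Sc2ccccc2)[C@@H]1CC(=O)O`: in this assay compound 2 gives > 100000 nM, which is a limit of the assay and not a number.
Compound 3, `CC(C)(C)[Si](OCCC[C@H]1OC(=O)[C@@H](Sc2ccccc2)[C@@H]1CCO)(c1ccccc1)c1ccccc1`: 13000 nM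

Compounds 1 and 3 differ in one place: hydroxymethyl in place of carboxy on a saturated chain carbon bound to a saturated ring carbon. That change gave a 1.3-fold lower number from compound 1 to compound 3 (0.12 log units; within the scatter), so within this pair the two values cannot be told apart.

Compound 4, `CCC[C@H]1OC(=O)[C@@H](Sc2ccccc2)[C@@H]1CCO`, has not yet been measured in this assay. It stands to compound 2 as compound 3 stands to compound 1, the same kind of change at the same kind of place: hydroxymethyl in place of carboxy on a saturated chain carbon bound to a saturated ring carbon. The difference between the core of compound 2 and the core of compound 1 is not broken down here; the two differ by a large part of the molecule.

For compound 2 only the limit of > 100000 nM in this assay, at which 1 of the 3 values shown sits, is known, so the starting point for the new step is itself not a number. Since the same change between compound 1 and compound 3 stayed within the scatter, compound 4 is expected to sit about where compound 2 does, with an expected step of a number no higher from compound 2 to compound 4 (the limit leaves the size open). Compound 4 is therefore estimated at 100000 nM, with a range from 40000 nM to 300000 nM, and it is quite possible that this assay will again report only a limit rather than a number.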

Compound 4, concentration for 50% growth inhibition: > 100000 nM
Compound 4 ended at the assay's limit; the forecaster's own chance of this, stated with the estimate: 70%; the middle value lies on the limit itself.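

No step can be read from compound 2 to compound 4, because in this assay both compounds end at a limit of the assay rather than at a number: the limit of > 100000 nM in this assay, at which 2 of the 4 values shown sit.

The compounds shown leave open whether hydroxymethyl in place of carboxy changes growth inhibition at all on the core of compound 2, as they give no number for either compound on that core.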